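Furan isomer swap in a cytotoxicity series on MT4 cells

The source may report more compounds than this note shows. Statements on the series, on what has been measured and on what is new or still open speak of the compounds shown alone.

Compound 1 `Cc1cc(C#N)cc(C)c1Oc1nc(Nc2ccc(C#N)cc2)ncc1-c1ccccc1` gives 31800 nM in an ADME assay on MT4 cells (Homo sapiens) for cytotoxicity, read by MTT assay, with a stated time of 5 days; a lower number here means that less compound is tolerated, a higher number that more compound is tolerated.
Compound 2 `COc1ccc(-c2cnc(Nc3ccc(C#N)cc3)nc2Oc2c(C)cc(C#N)cc2C)cc1` gives > 279000 nM in this assay, which is a limit of the assay rather than a number.
Compound 3 `Cc1cc(C#N)cc(C)c1Oc1nc(Nc2ccc(C#N)cc2)ncc1-c1ccoc1` gives 4980 nM in this assay.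

Of the two numbers available, compound 3 carries the lowest, and its nearest neighbour is compound 1, which sits higher: a 6.4-fold lower number from compound 1 to compound 3 (0.81 log units; beyond the scatter). The remaining value, that of compound 2, is a limit only (the limit of > 279000 nM in this assay, at which 1 of the 3 values shown sits).

Compound 4 `Cc1cc(C#N)cc(C)c1Oc1nc(Nc2ccc(C#N)cc2)ncc1-c1ccco1` has not yet been measured. It differs from compound 3 in one place: furan-2-yl in place of furan-3-yl on an aromatic carbon.

The measured steps that touch this position are the exchange of phenyl for furan-3-yl, a 6.4-fold lower number from compound 1 to compound 3 (0.81 log units; beyond the scatter), the exchange of hydrogen for methoxy on the phenyl, an at least 8.7-fold higher number from compound 1 to compound 2 (0.94 log units; beyond the scatter), and the exchange of 4-methoxyphenyl for furan-3-yl, an at least 56-fold lower number from compound 2 to compound 3 (1.74 log units; beyond the scatter). None of them moves the oxygen within a furan ring, so they give only indirect guidance. Since both isomers keep the same five-membered aromatic ring with one hetero atom and the same counts of donors and acceptors, the step from compound 3 to compound 4 is expected to stay within the scatter: a 1.2-fold higher number from compound 3 to compound 4 (0.08 log units; within the scatter).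

Compound 4 is therefore estimated at 6000 nM, within a range from 1500 nM to 25000 nM.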

Compound 4, half-maximal cytotoxic concentration: > 306000 nM
Compound 4: only a limit was reported; the forecaster's own chance of this, stated with the estimate: 5%; middle value at least 51-fold (1.70 log units) away from the limit.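

In this assay, moving the attachment point of the furan, with furan-2-yl in place of furan-3-yl, gives an at least 61-fold higher number from compound 3 to compound 4 (1.78 log units; beyond the scatter), so this position separates two groups that have identical atoms and identical counts of donors and acceptors. The value for compound 4 is a limit of the assay and not a number: the limit of > 306000 nM in this assay, at which 1 of the 4 values shown sits. Against the phenyl of compound 1 the two furans step in opposite directions, a 6.4-fold lower number from compound 1 to compound 3 (0.81 log units; beyond the scatter) for furan-3-yl and an at least 9.6-fold higher number from compound 1 to compound 4 (0.98 log units; beyond the scatter) for furan-2-yl, so among these compounds the five-membered ring alone does not set the direction of the step; the attachment point of the ring goes with it.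

As far as these compounds go, the step between compound 2 and compound 4 cannot be read, since both values are limits, and how far either lies beyond its limit stays open. Also open, from the compounds shown here alone, is what lies behind the gap between the two furans, and whether a similar gap would appear for thiophene or pyridine at this position, or for a furan carrying a methyl group.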